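This account rests on a few compounds, and the source may have more. Where it says the series, first, only, none or still open, it means among the compounds named here.

Of the compounds shown here, two with a shared core have been measured in an assay on isolated protein (strain Sprague-Dawley) for inhibition of Amine oxidase [flavin-containing] B (Rattus norvegicus), read by spectrophotometry, with a stated time of 5 min; a higher number here means a weaker inhibitor, a lower number a stronger inhibitor. Compound 1 `O=C(COc1cc(=O)oc2cc(OCc3cccc(Cl)c3)ccc12)N1CCCCC1` gives 38900 nM in this assay, while compound 2 `O=c1cc(Cl)c2ccc(OCc3cccc(Cl)c3)cc2o1` gives 20.9 nM. Among the measured compounds shown here, compound 2 thus holds the lowest of the two numbers; its only neighbour is compound 1, and the change that separates them, chloro in place of ((piperidin-1-yl)carbonyl)methoxy on an aromatic carbon, gave a 1900-fold lower number from compound 1 to compound 2 (3.27 log units; beyond the scatter).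

Compound 3 `CNc1cc(=O)oc2cc(OCc3cccc(Cl)c3)ccc12` has not yet been measured. It differs from compound 2 in one place: methylamino in place of chloro on an aromatic carbon. For the measured compounds named here, the one measured step bears on this only loosely, since the methylamino group that enters is much smaller than the group that left in going from compound 1 to compound 2, so a step of similar size is not expected. Still, compound 2 carries the smallest group so far at that carbon and shows the lowest number, so the expectation is a moderate rise in this assay, estimated as a 12-fold higher number from compound 2 to compound 3 (1.08 log units; beyond the scatter). Compound 3 is therefore expected to give about 250 nM in this assay, within a range from 30 nM to 2500 nM.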

Compound 3, half-maximal inhibitory concentration: 8.71 nM
Compound 3: middle estimate off by 29-fold (1.46 log units), on the high side, outside the stated range (below it).
By their numbers in this assay, from the lowest: compound 3; then compound 2; then compound 1.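

In this assay, methylamino in place of chloro on this aromatic carbon, opposite the ring oxygen, gave a 2.4-fold lower number from compound 2 to compound 3 (0.38 log units; beyond the scatter) and so took the lowest number of the series, a modest step but one beyond the usual scatter. With only compounds 1 and 2 in hand, the smallest group at this carbon also had the lowest number, but compound 3 goes against that reading: methylamino has more heavy atoms than chloro, and it brings a hydrogen-bond donor and acceptor that chloro lacks. Chloro is thus not needed here for a low number, and the distance from the ((piperidin-1-yl)carbonyl)methoxy compound grows, with the replacement by methylamino giving a 4500-fold lower number from compound 1 to compound 3 (3.65 log units; beyond the scatter) in this series.

The compounds shown leave open how an unsubstituted amino group, a dimethylamino group or a methoxy group would compare at this carbon, and so whether the lower number goes with the nitrogen itself or with the hydrogen on it. Nothing measured here explains why methylamino gives a lower number than chloro.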